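The source may report more compounds than this note shows. Statements on the series, on what has been measured and on what is new or still open speak of the compounds shown alone.

compound 1 `CCCCCC(CCO)n1cnc2c(Cl)ncnc21`: > 50000 nM
compound 2 `CCCCCC(CCO)n1cnc2c(Cl)nc(Cl)nc21`: 6170 nM
compound 3 `CCCCCC(CCO)n1cnc2c(N)nc(Cl)nc21`: > 50000 nM

In a functional assay on HCT-116 cells (Homo sapiens) for antiproliferative activity, read by MTT assay, with a stated time of 48 h (a lower number here means a stronger inhibitor, a higher number a weaker inhibitor), compound 2 gives 6170 nM, the only true number among these three. Compound 1 and compound 3 each stand at a limit of the assay, not at a number: the limit of > 50000 nM in this assay, at which 2 of the 3 values shown sit.

Among the compounds with values here, two measured steps touch compound 2. One is an at least 8.1-fold lower number from compound 1 to compound 2 (0.90 log units; beyond the scatter), and the other is an at least 8.1-fold higher number from compound 2 to compound 3 (0.90 log units; beyond the scatter). Both changes sit on an aromatic carbon of the shared core, and together they show that this series can respond clearly to a single change there. Neither step alters the chain, so neither gives a size for the change considered next.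

Compound 4 `CCCCCCCC(CCO)n1cnc2c(Cl)nc(Cl)nc21` keeps the core of compound 2 and differs only in the chain: ethyl in place of hydrogen on a saturated chain carbon, six bonds along the chain from an aromatic nitrogen. In words, this is ethyl in place of hydrogen on a saturated chain carbon, six bonds along the chain from an aromatic nitrogen. With no measured change on the chain to draw on, the expectation stays anchored to compound 2 at 6170 nM, and no step beyond the scatter is expected in this assay. The expected step, a slightly lower number if anything, is a 1.5-fold lower number from compound 2 to compound 4 (0.19 log units; within the scatter). The estimated value for compound 4 is 4000 nM, with an expected range from 1500 nM to 13000 nM.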

Compound 4, half-maximal inhibitory concentration: 12800 nM
The estimate for compound 4 lay 3.2-fold (0.51 log units) below the measured number; the range from low to high includes it.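

The chain turns out not to be a silent part of these molecules. In this assay, ethyl in place of hydrogen on a saturated chain carbon, six bonds along the chain from an aromatic nitrogen, gives a 2.1-fold higher number from compound 2 to compound 4 (0.32 log units; beyond the scatter), so this position responds to a change of just two carbon atoms, modestly and towards weaker inhibition, and compound 4 still gives a true number rather than a limit. The compounds shown contain nothing that says why lengthening the chain has this effect.

On these data alone, one step on the chain is a single comparison and not a trend, so it remains open whether a still longer chain, a shorter chain, or an amine or a carboxylic acid at this position would move the number further, leave it unchanged or reverse the direction. As far as these compounds go, it is also open whether the ethyl step would have the same size on the core of compound 1 or compound 3, since each of those compounds stands at a limit and offers no true number to start from.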